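This account rests on a few compounds, and the source may have more. Where it says the series, first, only, none or still open, it means among the compounds named here.

Compound 2 `COc1cc(-c2nn(-c3cccc(NC(=O)Nc4ccc(Cl)c(Cl)c4)c3)cc2-c2ccncc2)ccc1Cl` is one of three ureas sharing a core; in a functional assay on Malme-3M cells (Homo sapiens) for inhibition, read by sulforhodamine B assay, with a stated time of 48 h (on this read-out lower numbers stand for stronger inhibition of growth and higher numbers for weaker inhibition of growth), compound 2 gives 2420 nM. Compound 1 `COc1cc(-c2nn(-c3cccc(NC(=O)Nc4cc(C(F)(F)F)cc(C(F)(F)F)c4)c3)cc2-c2ccncc2)ccc1Cl` gives 2170 nM in this assay, a value within the scatter of compound 2. Among the compounds with values here, compound 3 `O=C(Nc1cccc(-n2cc(-c3ccncc3)c(-c3ccc(Cl)c(O)c3)n2)c1)Nc1ccc(Cl)c(Cl)c1` gives 8100 nM, and the only single-point step recorded, a 3.3-fold higher number from compound 2 to compound 3 (0.52 log units; beyond the scatter), concerns a change at the oxygen rather than the urea. Compound 4 `COc1cc(-c2nn(-c3cccc(NC(=O)c4ccc(Cl)c(C(F)(F)F)c4)c3)cc2-c2ccncc2)ccc1Cl` differs from compound 2 by 4-chloro-3-(trifluoromethyl)phenyl in place of (3,4-dichlorophenyl)amino on a carbonyl carbon. Within the data shown here, none of the measured steps touches this linker, and compound 1 and compound 2 show that varying the distal aryl halogens changes little, so the step is expected to be a 1.2-fold higher number from compound 2 to compound 4 (0.09 log units; within the scatter). Compound 4 is therefore estimated at 3000 nM, within a range from 1000 nM to 9000 nM.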

Compound 4, concentration for total growth inhibition: 19700 nM
Compound 4: the middle estimate sits 6.6-fold (0.82 log units) below what was measured, outside the stated range (above it).
By their numbers in this assay, from the lowest: compounds 1 and 2 (each within the scatter of the next); then compound 3; then compound 4.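

In this assay, within the data shown here, the linker position proves sensitive: an 8.1-fold higher number from compound 2 to compound 4 (0.91 log units; beyond the scatter) is the first measured change at the carbonyl carbon, and it takes compound 4 out of the urea series. The change removes the amino nitrogen with its hydrogen-bond donor and also alters the aryl substituents, so the two effects cannot be separated here. No evidence is available that bears on the cause of this loss.

Going by these compounds, it remains open whether a 3,4-dichlorophenyl group on the carbonyl carbon would behave like compound 4. On these data alone, it is also open whether a methylene or methylamino link would restore the level of compound 2.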